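Phenylsulfanyl in place of chloro on the side chain

The source may report more compounds than this note shows. Statements on the series, on what has been measured and on what is new or still open speak of the compounds shown alone.

Within the data shown here, compound 1 `O=C(Cc1c[nH]c2ccccc12)N/N=C1\C[C@@H](c2ccc(O)cc2)Oc2cc(O)cc(O)c21` and compound 2 `COc1cc(O)c2c(c1)O[C@H](c1ccc(OCC(O)CCl)cc1)CC2=O` are the only measured members in a functional assay on L5178Y cells (Mus musculus) for inhibition, read by MTT assay, with a stated time of 24 h; a higher number here means a weaker inhibitor, a lower number a stronger inhibitor. Compound 1 gives >= 11300 nM, which is a limit of the assay and not a number. Compound 2 gives >= 11300 nM, also a limit and not a number. The measured set as a whole shows (the limit of >= 11300 nM in this assay, at which 2 of the 2 values shown sit), so no order can be drawn between the two compounds.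

Compound 3 `COc1cc(O)c2c(c1)O[C@H](c1ccc(OCC(O)CSc3ccccc3)cc1)CC2=O` differs from compound 2 in one place: phenylsulfanyl in place of chloro on a saturated chain carbon, two bonds along the chain from an oxygen on a saturated carbon. Phenylsulfanyl stands in place of chloro on a saturated chain carbon, two bonds along the chain from an oxygen on a saturated carbon. Among the measured compounds shown here, no measured step covers this replacement. The only anchor for an expectation is compound 2 at >= 11300 nM, a limit. In this assay no change beyond the scatter is expected in either direction, and the estimated step is an at least 1.0-fold lower number from compound 2 to compound 3 (0.01 log units; that floor lies within the scatter). For compound 3 the estimated half-maximal inhibitory concentration is 11000 nM, with an expected range from 3500 nM to 25000 nM.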

Compound 3, half-maximal inhibitory concentration: >= 11300 nM
Compound 3: a limit, no number; the forecaster's own chance of this, stated with the estimate: 60%; middle value at least 1.0-fold (0.01 log units) away from the limit.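

In this assay compound 2 and compound 3 both sit at a limit and not at a number, so the step from chloro to phenylsulfanyl cannot be read: the limit of >= 11300 nM in this assay, at which 3 of the 3 values shown sit.

The compounds shown leave open whether any member of this series gives a readable half-maximal inhibitory concentration in this assay and how far replacing chloro with phenylsulfanyl moves it.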